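Methoxy Addition on Vinyl Sulfone Amines and Nitro Analogues

The source may report more compounds than this note shows. Statements on the series, on what has been measured and on what is new or still open speak of the compounds shown alone.

Measured compounds:
compound 1 `COc1ccc(/C=C/S(=O)(=O)Cc2ccc(OC)c(N)c2)cc1` gives 2500 nM in a functional assay on DU-145 cells (Homo sapiens) for cytotoxicity, read by trypan blue exclusion, with a stated time of 96 h; a higher number here means a weaker inhibitor, a lower number a stronger inhibitor
compound 2 `COc1ccc(CS(=O)(=O)/C=C/c2c(OC)cccc2OC)cc1[N+](=O)[O-]` gives 20000 nM in this assay
compound 3 `COc1ccc(/C=C/S(=O)(=O)Cc2ccc(OC)c(N)c2)c(OC)c1` gives 500 nM in this assay

Of the compounds shown here, three have been measured in this assay. Compound 2 stands with the highest number of the three; compound 1 is nearest to it and compound 3 furthest. The difference between the core of compound 1 and the core of compound 2 is not broken down here.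

Within the pair built on the core of compound 1, the change methoxy in place of hydrogen on an aromatic carbon gave a 5.0-fold lower number from compound 1 to compound 3 (0.70 log units; beyond the scatter), a modest step in favour of compound 3.

Compound 4 `COc1cc(OC)c(/C=C/S(=O)(=O)Cc2ccc(OC)c([N+](=O)[O-])c2)c(OC)c1` has not yet been measured in this assay. It differs from compound 2 by methoxy in place of hydrogen on an aromatic carbon. Going by the values given here, this is the same kind of change as the one from compound 1 to compound 3, but the surroundings are not the same: in compound 3 the entering methoxy sits ortho to a large group and meta to a methoxy group, whereas in compound 4 it sits meta to two methoxy groups and para to a large group.

Among the compounds with values here, compound 4 is estimated to give a step of a 2.5-fold lower number from compound 2 to compound 4 (0.40 log units; beyond the scatter) in this assay, a smaller step than the one from compound 1 to compound 3, because a 5.0-fold lower number from compound 1 to compound 3 (0.70 log units; beyond the scatter) arose on a different core and at a different place on the ring, and the high number of compound 2 in this assay offers no direct precedent. Compound 4 is therefore expected to fall near 8000 nM, with a range from 3000 nM to 25000 nM.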

Compound 4, half-maximal inhibitory concentration: 2500 nM
Compound 4: middle estimate off by 3.2-fold (0.51 log units), on the high side, outside the stated range (below it).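

In this assay, methoxy in place of hydrogen on an aromatic carbon gave an 8.0-fold lower number from compound 2 to compound 4 (0.90 log units; beyond the scatter), so the number fell on this second core as it did on the core of compound 1. Set side by side, the two steps agree within the scatter: the same change on two cores in this assay, a 5.0-fold lower number (0.70 log units; beyond the scatter) from compound 1 to compound 3 and an 8.0-fold lower number (0.90 log units; beyond the scatter) from compound 2 to compound 4, 1.6-fold (0.20 log units) apart, within the scatter of two such steps. Within this series, then, the change carried over from one core to the other in both direction and approximate size, but this rests on only two pairs, and the entering methoxy stands at a different place on the ring in each, here meta to two methoxy groups and para to a large group, so the result does not show that the step would hold on other cores or at other ring places, nor does it explain why the number falls.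

On these data alone, whether an ethoxy group, a hydroxyl group or a fluorine atom at the same place would give a step of similar size remains open. Also open, as far as these compounds go, is how the methoxy change would behave on a core with an acetamide or a carboxylic acid where these compounds have the amine or the nitro group.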